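Isobutyl on the sulfonamide nitrogen: clearance notes

This account rests on a few compounds, and the source may have more. Where it says the series, first, only, none or still open, it means among the compounds named here.

Compound 1 (`Cc1ccc(S(=O)(=O)N2CCOCC2)cc1C#Cc1cc(Cl)ccc1OCC(=O)O`) and compound 2 (`Cc1ccc(S(=O)(=O)N(C)C)cc1C#Cc1cc(Cl)ccc1OCC(=O)O`) differ in one place, with dimethylamino in place of morpholin-4-yl on the sulfonyl sulfur. In an in vitro ADME assay on microsomes from liver (Homo sapiens) for metabolic stability, read by LC-MS, tested at 1 uM (a lower number here means slower removal, a higher number faster removal of the compound), compound 1 gives < 10 mL.min-1.g-1 and this is a limit of the assay, not a number. Compound 2 gives < 10 mL.min-1.g-1 and this too is only a limit. Within the data shown here, the series so far therefore offers only the limit of < 10 mL.min-1.g-1 in this assay, at which 2 of the 2 values shown sit, as its reading.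

Compound 3 (`Cc1ccc(S(=O)(=O)N(C)CC(C)C)cc1C#Cc1cc(Cl)ccc1OCC(=O)O`) comes from compound 2 by one change. That change is isopropyl in place of hydrogen on a saturated chain carbon bound to a sulfonamide nitrogen and, cut one bond further out, it reads dimethylamino to isobutyl(methyl)amino.

Among the measured compounds shown here, the only measured step that bears on it is a step that the two limits leave unreadable from compound 1 to compound 2 and it has no size to carry over. A small rise in this assay is expected on that thin basis, perhaps none beyond the scatter, and another limit is a real possibility. The estimated step of an at least 1.1-fold higher number from compound 2 to compound 3 (0.04 log units; that floor lies within the scatter) is therefore loose. For compound 3 the expected intrinsic clearance in microsomes is 11 mL.min-1.g-1 with an estimated range from 5 mL.min-1.g-1 to 25 mL.min-1.g-1 for now.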

Compound 3, intrinsic clearance in microsomes: 79 mL.min-1.g-1
Compound 3: the middle estimate sits 7.2-fold (0.86 log units) below what was measured; the measured number lies above the stated range.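

In this assay, isobutyl(methyl)amino in place of dimethylamino on the sulfonyl sulfur gives the series its first readable step, an at least 7.9-fold higher number from compound 2 to compound 3 (0.89 log units; beyond the scatter), so added carbon on the saturated chain at the sulfonamide nitrogen can move this read-out well clear of the limit. The same group set against the morpholin-4-yl of compound 1 gives an at least 7.9-fold higher number from compound 1 to compound 3 (0.89 log units; beyond the scatter), which shows that the rise does not depend on which of the two smaller sulfonyl substituents serves as the reference. Both steps are floors and not sizes, as each starts from a limit of the assay and not from a number, and the step between compound 1 and compound 2 still cannot be read: the limit of < 10 mL.min-1.g-1 in this assay, at which 2 of the 3 values shown sit.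

The compounds shown do not separate the isopropyl branch from the added carbon as such, and a straight butyl or a propyl on the same nitrogen would bear on that. They also leave open whether a hydroxyl at the end of that chain, or a cyclopropylmethyl in place of the isobutyl, would stay near compound 3 in this assay or fall back to a limit.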